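This account rests on a few compounds, and the source may have more. Where it says the series, first, only, none or still open, it means among the compounds named here.

In a functional assay on HL-60 cells (Homo sapiens) for inhibition, read by MTT assay, with a stated time of 72 h (a lower number here means a stronger inhibitor, a higher number a weaker inhibitor), compound 1 `Cc1nc(-c2ccc(F)cc2)c(C(=O)N2CCN(c3cccc(Cl)c3)CC2)o1` gives 40.1 nM, the lower of the two numbers available in this small set. Compound 3 `Cc1ccc(C)c(N2CCN(C(=O)c3oc(C)nc3-c3ccc(F)cc3)CC2)c1` gives 358 nM. Among the measured compounds shown here, compound 2 `Cc1nc(-c2ccc(Cl)cc2)c(C(=O)N2CCN(c3cccc(C(=O)C(C)C)c3)CC2)o1` is recorded as "not active" (no number reported), with no number to set beside the others, and it differs from compound 1 in more than one place, so it offers no clean step.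

Compound 4 `COc1ccc(-c2nc(C)oc2C(=O)N2CCN(c3cccc(Cl)c3)CC2)cc1` keeps the 3-chlorophenyl group of compound 1 and changes one substituent: methoxy in place of fluoro on an aromatic carbon. In words, this is methoxy in place of fluoro on an aromatic carbon, or 4-fluorophenyl to 4-methoxyphenyl.

For the measured compounds named here, no measured step touches this place. The only one available, 2,5-dimethylphenyl in place of 3-chlorophenyl on an amine nitrogen in a ring, is an 8.9-fold higher number from compound 1 to compound 3 (0.95 log units; beyond the scatter). It shows that one change in this set can move the number beyond the scatter, but it gives no direct guide to the new substituent. A modest rise in this assay, smaller than that step, is therefore expected, although a result within the scatter of compound 1 would not be surprising. The expected change is a 2.5-fold higher number from compound 1 to compound 4 (0.40 log units; beyond the scatter). Compound 4 is estimated at 100 nM, with an expected range of 25 nM to 350 nM.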

Compound 4, half-maximal inhibitory concentration: "not active" (no number reported)
Compound 4: no number reported; there is nothing to compare the estimate with.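

Among the compounds shown here, compound 4 is recorded in this assay as "not active", with no number reported, and no step from compound 1 to compound 4 can be read. No available evidence bears on this result. The compounds shown leave open how far 4-fluorophenyl to 4-methoxyphenyl moves the number on the shared core.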